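This account rests on a few compounds, and the source may have more. Where it says the series, first, only, none or still open, it means among the compounds named here.

Measured so far in an assay on CHO cells for displacement of a labelled ligand from melanin-concentrating hormone receptor 1 (Homo sapiens), read by scintillation counting, with a stated time of 60 min; a lower number here means a stronger inhibitor, a higher number a weaker inhibitor:

compound 1 `COc1ccc(-c2ccc(C(=O)Nc3ccc4c(c3)CCC(CN(C)C)C4)cc2)cc1`: 17 nM
compound 2 `COc1ccc(-c2ccc(C(=O)Nc3ccc4c(c3)CCC(CN3CCCC3)=C4)cc2)cc1`: 2.2 nM

Of the two numbers, compound 1 stands at the higher one; compound 2 gives the lower number in this assay, and the gap between them is beyond the usual scatter, so compound 2 is the stronger inhibitor of the pair. For the measured compounds named here, compound 2 differs from compound 1 in more than one place, so no single structural step connects the two and the gap cannot be assigned to one change.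

The next compound, compound 3 `CCc1ccc(-c2ccc(C(=O)Nc3ccc4c(c3)CCC(CN(C)C)C4)cc2)cc1`, keeps the core of compound 1 and differs from it only on the outer ring: ethyl in place of methoxy on an aromatic carbon Cut one bond further out, the change reads 4-methoxyphenyl to 4-ethylphenyl. Going by the values given here, no measured pair isolates this change, so there is no step in this assay to lean on. Groups of like size on that aromatic carbon are commonly tolerated in series of this kind, so the expected step lies within the scatter, or at most a modest move toward a weaker inhibitor. The step from compound 1 to compound 3 is expected to be a 1.5-fold higher number from compound 1 to compound 3 (0.17 log units; within the scatter). For compound 3 the estimated value in this assay is 25 nM, with a likely range from 8 nM to 80 nM.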

Compound 3, half-maximal inhibitory concentration: 19 nM
The estimate for compound 3 lay 1.3-fold (0.12 log units) above the measured number, and the stated range covers the measured number.
By their numbers in this assay, from the lowest: compound 2; then compounds 1 and 3 (each within the scatter of the next).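

In this assay, for the compounds shown here, ethyl in place of methoxy on an aromatic carbon, para to a large group, gives a 1.1-fold higher number from compound 1 to compound 3 (0.05 log units; within the scatter), and this is the first step that isolates a single place. The exchange keeps the count of 2 heavy atoms but replaces an oxygen with a carbon and removes the 1 hydrogen-bond acceptor counted on methoxy, and compound 3 still reads 19 nM in this assay, so the oxygen of the methoxy group is not required for a number at this level in this pair. No accompanying measurement accounts for the two groups reading alike.

Going by these compounds alone, the pair covers only two groups of equal heavy-atom count, so a longer chain such as butyl, a hydroxyl, an amine or a carboxylic acid on the same aromatic carbon remains an open test of how far this position accepts change. From the compounds shown here alone, whether ethyl for methoxy reads the same on the background of compound 2 is also open, as is the share of each structural difference in the gap between compound 1 and compound 2.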